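Capping a phenol: from compound 2 toward compound 3

The compounds below may be only part of what the source reports. "The series", "measured", "known", "first", "only" and "open" are said of these compounds alone.

Compound 1 `COc1cc(-c2cc(-c3cc(C(C)C)c(O)cc3C)[nH]c(=O)c2C#N)cc(OC)c1OC`: 71%
Compound 2 `COc1cc(-c2cc(-c3cc(C(C)C)c(O)cc3C)[nH]c(=O)c2C#N)ccc1O`: 37.5%

Of the compounds shown here, two sharing one core have been measured in a functional assay for inhibition, tested at 60 ug/mL; on this read-out lower numbers stand for a weaker effect and higher numbers for a stronger effect at the one concentration tested. Compound 1 carries a 3,4,5-trimethoxyphenyl group and in this assay compound 1 gives 71%. Compound 2 carries a 4-hydroxy-3-methoxyphenyl group instead, and in this assay compound 2 gives 37.5%. Compound 2 thus stands lowest of the two numbers; its nearest neighbour is compound 1, which lies higher by a gap beyond the usual scatter.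

Compound 3 `COc1ccc(-c2cc(-c3cc(C(C)C)c(O)cc3C)[nH]c(=O)c2C#N)cc1OC` has not yet been measured. It differs from compound 2 in one place: methyl in place of hydrogen on an oxygen on an aromatic ring. Compound 3 therefore carries a 3,4-dimethoxyphenyl group, which sits between compound 2 and the fully methylated compound 1 in the number of methoxy groups.

Since compound 1 gives 71% and compound 2 gives 37.5%, an upward step from compound 2 to compound 3 is expected, of moderate size, estimated at a number 17.5 percentage points higher from compound 2 to compound 3 (beyond the scatter). The value expected for compound 3 in this assay is 55%, with a range from 35% to 75%.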

Compound 3, a percentage reported as inhibition, at one concentration (the size of the read-out at that concentration, not a potency): 52%
The estimate for compound 3 lay 3 percentage points above the measured number; measured number inside the range.
By their numbers in this assay, from the lowest: compound 2; then compound 3; then compound 1.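

The hydroxy to methoxy change now has a size of its own in this assay: a number 14.5 percentage points higher from compound 2 to compound 3 (beyond the scatter). The earlier pair could not show this, since compound 1 and compound 2 differ in more than one place. A second single change can now be read as well, as taking one methoxy group off the ring of compound 1 leaves compound 3, with a number 19 percentage points lower from compound 1 to compound 3 (beyond the scatter), so among these three compounds alone, more methoxy groups on this ring go with a higher number and none goes against that order. Nothing shown here gives a reason for either step.

Still open, going by these compounds, is what a different group on that oxygen would give, such as an ethyl or a benzyl in place of the methyl, or what an amine would give in place of the hydroxy. The compounds shown also leave open whether capping this oxygen would give a step of similar size on a ring with no other methoxy group, and how these compounds would compare across a range of concentrations rather than at the one tested.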